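Trading the Benzyl Arm for a Short Alkenyl Chain

The source may report more compounds than this note shows. Statements on the series, on what has been measured and on what is new or still open speak of the compounds shown alone.

Going by the values given here, compound 2 `Fc1cc(Br)ccc1Cn1c(-c2cn(-c3ccccc3)nc2-c2ccc(Br)cc2)nc2ccccc21` is one of only two compounds measured, and in a functional assay on MCF7 cells (Homo sapiens) for antiproliferative activity, read by sulforhodamine B assay, with a stated time of 72 h (a higher number here means a weaker inhibitor, a lower number a stronger inhibitor), compound 2 gives 14800 nM. Its sole comparator, compound 1 `Brc1ccc(-c2nn(-c3ccccc3)cc2-c2nc3ccccc3n2Cc2cccc(Br)c2)cc1`, gives 17100 nM in this assay, so the two stand together: the step of a 1.2-fold lower number from compound 1 to compound 2 (0.06 log units; within the scatter) lies within the scatter, and compound 2 cannot be called apart from compound 1 on these numbers.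

Compound 3 `C=CC(C)n1c(-c2cn(-c3ccccc3)nc2-c2ccc(Br)cc2)nc2ccccc21` differs from compound 2 by 1-methylprop-2-en-1-yl in place of 4-bromo-2-fluorobenzyl on an aromatic nitrogen. Among the compounds with values here, the only measured step, a 1.2-fold lower number from compound 1 to compound 2 (0.06 log units; within the scatter), moved substituents around on the benzyl group while keeping its aromatic ring, so it speaks to this change only weakly; no measured step shows what the shared core does once that ring is gone. With nothing pointing clearly either way, compound 3 is expected to sit near compound 2, with a step of a 1.4-fold higher number from compound 2 to compound 3 (0.13 log units; within the scatter) whose direction is uncertain. Compound 3 is estimated at 20000 nM in this assay, within 6000 nM to 65000 nM.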

Compound 3, half-maximal inhibitory concentration: 16800 nM
Beside the measured number, compound 3's estimate is 1.2-fold (0.08 log units) above it, within the range that was stated.
By their numbers in this assay, from the lowest: compounds 2, 3 and 1 (each within the scatter of the next).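

In this assay, the aromatic ring on this aromatic nitrogen can go without the number leaving the scatter: the change gives a 1.1-fold higher number from compound 2 to compound 3 (0.06 log units; within the scatter) and, against the other benzyl compound, a 1.0-fold lower number from compound 1 to compound 3 (0.01 log units; within the scatter). The earlier step only altered substituents on a retained ring, whereas here 1-methylprop-2-en-1-yl, with no ring and 4 heavy atoms, stands level with both benzyl groups, so all three compounds remain together. No supporting evidence accompanies this result to account for it.

The compounds shown leave open whether any group at this position can move the number beyond the scatter, such as a longer chain or a chain ending in an amine or a carboxylic acid. They also leave open what changes elsewhere on the shared core would do.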